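Chlorophenyl position and whole-animal inhibition: estimate for compound 3

The source may hold more compounds than are shown below. What is called first, only, known or untested is meant among the compounds shown, and "the series" means these compounds.

Measured so far:
compound 1, `CN(C)CCCCOc1ccccc1/C=C/c1ccccc1Cl` — 50%
compound 2, `CN(C)CCCCOc1ccccc1/C=C/c1cccc(Cl)c1` — 23.9%

In a functional assay on the whole organism with Mus musculus as the target, at a dose of 50 mg/kg by the oral route (on this read-out lower numbers stand for less inhibition and higher numbers for more inhibition at the one dose given (going by the name of the read-out)), compound 1 gives 50% and compound 2 gives 23.9%. Among the compounds with values here, compound 2 thus stands at the lower of the two numbers recorded in this assay, and its only neighbour is compound 1. Within the data shown here, the single step seen so far is a number 26.1 percentage points lower from compound 1 to compound 2 (beyond the scatter), a modest fall that lies beyond the scatter.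

Compound 3, `CN(C)CCCCOc1ccccc1/C=C/c1ccc(Cl)cc1`, has not been measured in this assay. It differs from compound 2 in one place: 4-chlorophenyl in place of 3-chlorophenyl on a double-bonded chain carbon bound to a double-bonded chain carbon. The step from compound 1 to compound 2 is the only one that bears on this change, since it too moved the chlorine within the same ring, and it cost a number 26.1 percentage points lower from compound 1 to compound 2 (beyond the scatter). Two numbers do not settle whether a further shift of the chlorine continues that fall, reverses it, or leaves the number unchanged within the scatter. The expected step is therefore a number 4.1 percentage points higher from compound 2 to compound 3 (within the scatter), small and uncertain in sign. Compound 3 is estimated at 28%, with a range from 5% to 55%.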

Compound 3, a percentage reported as inhibition, in the whole organism at one dose (the size of the read-out at that dose, not a potency): 62.5%
For compound 3 the middle estimate is 34.5 percentage points below the measured one, and the stated range ends below it.
By their numbers in this assay, from the lowest: compound 2; then compound 1; then compound 3.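

In this assay the position of the chlorine on this ring does not follow a one-way trend. The fall from 2-chlorophenyl to 3-chlorophenyl is more than reversed with 4-chlorophenyl, a number 38.6 percentage points higher from compound 2 to compound 3 (beyond the scatter), and the series also gains over its earlier top value, a number 12.5 percentage points higher from compound 1 to compound 3 (beyond the scatter). Compound 3 therefore stands highest of the three, and compound 2, with 3-chlorophenyl, stands lowest, with all the steps among the three beyond the scatter; since these compounds have the same atoms joined differently, the placement of the chlorine on the ring alone is enough to shift this whole-animal read-out substantially at the one dose given. No measurement available here accounts for this order, so its cause remains unaddressed.

On these data alone, whether the same order of 4-chlorophenyl, 2-chlorophenyl and 3-chlorophenyl would hold for another group on the ring, such as fluorine or methoxy, remains open. Also open, as far as these compounds go, is how the numbers respond to a shorter or longer chain carrying the amine, or to a pyrrolidine in place of the dimethylamino group.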